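Moving From Cyanophenyl To A Carbamoylpyridyl Oxazole Substituent

A few compounds are considered here, and "the series" means these few. Any claim that something is new, unique, unknown or untested is made for them only; others in the source may bear on it.

Compound 1 `N#Cc1ccccc1-c1cnc(C(=O)CCCCCCc2ccccc2)o1`: 130 nM
Compound 2 `N#Cc1cccc(-c2cnc(C(=O)CCCCCCc3ccccc3)o2)c1`: 15 nM
Compound 3 `Cc1ccc(-c2cnc(C(=O)CCCCCCc3ccccc3)o2)nc1`: 2.8 nM

In an assay (Rattus norvegicus) for inhibition of Fatty-acid amide hydrolase 1 (Homo sapiens) (a lower number here means a stronger inhibitor, a higher number a weaker inhibitor), compound 1 gives the highest of the three numbers. Its nearest neighbour is compound 2, reached by an 8.7-fold lower number from compound 1 to compound 2 (0.94 log units; beyond the scatter); the furthest is compound 3, reached by a 46-fold lower number from compound 1 to compound 3 (1.67 log units; beyond the scatter). Compound 4 `NC(=O)c1cccc(-c2cnc(C(=O)CCCCCCc3ccccc3)o2)n1` differs from compound 1 by 6-carbamoylpyridin-2-yl in place of 2-cyanophenyl on an aromatic carbon. For the measured compounds named here, the step that bears most on this change is the one from compound 1 to compound 3, where a pyridin-2-yl group in place of 2-cyanophenyl brought a large gain; the step from compound 1 to compound 2 adds a modest gain for moving the ring substituent. A large downward step is therefore expected, a 26-fold lower number from compound 1 to compound 4 (1.41 log units; beyond the scatter). Compound 4 is estimated at 5 nM, in the range 1.5 nM to 20 nM.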

Compound 4, inhibition constant: 1 nM
The estimate for compound 4 lay 5.0-fold (0.70 log units) above the measured number; the measured number lies below the stated range.
By their numbers in this assay, from the lowest: compound 4; then compound 3; then compound 2; then compound 1.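

In this assay the position next to the ring oxygen accepts the 6-carbamoylpyridin-2-yl group (a 130-fold lower number from compound 1 to compound 4 (2.11 log units; beyond the scatter)), and the number falls further than with the 5-methylpyridin-2-yl group (a 2.8-fold lower number from compound 3 to compound 4 (0.45 log units; beyond the scatter)). The gain over the 3-cyanophenyl group is also beyond the scatter (a 15-fold lower number from compound 2 to compound 4 (1.18 log units; beyond the scatter)). Nothing measured here accounts for these steps.

The compounds shown leave open whether a carboxylic acid or a methyl ester in place of the carbamoyl group would keep this number. They also leave open whether a 3-carbamoylphenyl group, without the ring nitrogen, would match it.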